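Loss of the indole in compound 1: working notes

The compounds below may be only part of what the source reports. "The series", "measured", "known", "first", "only" and "open" are said of these compounds alone.

Measured in a functional assay on A549 cells (Homo sapiens) for inhibition, read by CCK-8 assay, with a stated time of 48 h; on this read-out lower numbers stand for stronger inhibition and higher numbers for weaker inhibition:
compound 1 `COc1cc(-c2ccnc3cc(-c4c[nH]c5ccccc45)nn23)cc(OC)c1OC` gives 29 nM
compound 2 `COc1cc(-c2ccnc3cc(-c4cn(C)c5ccccc45)nn23)cc(OC)c1OC` gives 1340 nM
compound 3 `COc1cc(-c2ccnc3cc(-c4cccc(C)c4)nn23)cc(OC)c1OC` gives 5730 nM

Compound 1 stands lowest of the three numbers. Its nearest neighbour is compound 2, a 46-fold higher number from compound 1 to compound 2 (1.66 log units; beyond the scatter); its furthest is compound 3, a 200-fold higher number from compound 1 to compound 3 (2.30 log units; beyond the scatter). Compound 4 `COc1cc(-c2ccnc3cc(-c4ccc(C(C)=O)cc4)nn23)cc(OC)c1OC` is not yet measured; it differs from compound 1 in one place: 4-acetylphenyl in place of 1H-indol-3-yl on an aromatic carbon. Both measured steps bear on this change. Taking away only the hydrogen on the aromatic nitrogen gave a large rise, and swapping the whole 1H-indol-3-yl for a plain 3-methylphenyl gave a still larger one, with the two single-ring compounds separated by a 4.3-fold higher number from compound 2 to compound 3 (0.63 log units; beyond the scatter). A large rise in this assay is therefore expected for compound 4, a 100-fold higher number from compound 1 to compound 4 (2.01 log units; beyond the scatter). Compound 4 is estimated at 3000 nM, within 800 nM to 10000 nM.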

Compound 4, half-maximal inhibitory concentration: 4100 nM
Estimate against measurement, compound 4: 1.4-fold (0.14 log units) below; measured number inside the range.
By their numbers in this assay, from the lowest: compound 1; then compound 2; then compounds 4 and 3 (each within the scatter of the next).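

In this assay, 4-acetylphenyl, with a hydrogen-bond acceptor and no donor, does not recover what the loss of 1H-indol-3-yl costs (a 140-fold higher number from compound 1 to compound 4 (2.15 log units; beyond the scatter)). The two single-ring groups at this place cannot be told apart (a 1.4-fold lower number from compound 3 to compound 4 (0.15 log units; within the scatter)), while 1-methyl-1H-indol-3-yl still keeps a modest margin over 4-acetylphenyl (a 3.1-fold higher number from compound 2 to compound 4 (0.49 log units; beyond the scatter)). No measurement to hand explains any of these steps.

Going by these compounds, it remains open whether a phenyl ring carrying an amine or a carboxylic acid would behave like these two single-ring groups. Also open, on these data alone, is how an indole bearing fluorine on its six-membered ring, with the ring hydrogen on nitrogen kept, would compare with compound 1.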